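Cytotoxicity notes on the shared core series

This account rests on a few compounds, and the source may have more. Where it says the series, first, only, none or still open, it means among the compounds named here.

Measured so far:
compound 1 `CCOC(=O)C1(Cc2ccccc2)CN(c2ccccc2)Cc2nnn(Cc3ccc(F)cc3)c21` gives >= 100000 nM
compound 2 `CCOC(=O)C1(Cc2ccccc2)CN(c2ccccc2)Cc2nnn(Cc3ccc(Cl)c(Cl)c3)c21` gives > 100000 nM

Both compounds were tested in an ADME assay on HEL cells (Homo sapiens) for cytotoxicity, read by microscopy, with a stated time of 3 days; a higher number here means that more compound is tolerated, a lower number that less compound is tolerated. Compound 1 reaches only a limit of the assay, >= 100000 nM. Compound 2 likewise reaches only a limit, > 100000 nM. Going by the values given here, the one measured step, a step that the two limits leave unreadable from compound 1 to compound 2, is therefore not readable as a number, and the two limits, the limit of > 100000 nM in this assay, at which 1 of the 2 values shown sits, and (the limit of >= 100000 nM in this assay, at which 1 of the 2 values shown sits), together say only that neither compound showed toxicity within the tested range.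

Compound 3 `CCCCCCCCn1nnc2c1C(Cc1ccccc1)(C(=O)OCC)CN(c1ccccc1)C2` is next for this assay. Its difference from compound 2 is heptyl in place of 3,4-dichlorophenyl on a saturated chain carbon bound to an aromatic nitrogen. Among the compounds with values here, no measured step bears directly on this change, since the only step known is unreadable. With both measured compounds sitting at a limit, the expectation for compound 3 is that it also sits at or near that limit; a step of a number no higher from compound 2 to compound 3 (the limit leaves the size open) is expected, which amounts to no readable movement. The estimate for compound 3 in this assay is 100000 nM, with a range from 30000 nM to 200000 nM, and a good chance that only a limit is reported again.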

Compound 3, minimum cytotoxic concentration: >= 20000 nM
Compound 3 was reported as a limit; the forecaster's own chance of this, stated with the estimate: 65%; the middle value lies beyond the limit too.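

Compound 3 gives >= 20000 nM, which is a limit and not a number. Going by these compounds alone, compound 1, compound 2 and compound 3 all stand at limits, so no step among them can be read. The compounds shown leave open whether heptyl in place of either aryl group changes the minimum cytotoxic concentration in this assay.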